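The source may hold more compounds than are shown below. What is called first, only, known or untested is meant among the compounds shown, and "the series" means these compounds.

Compound 1 `Cc1occc1-c1nnc(SCC(=O)Nc2ccc(F)cc2)n1Cc1ccco1`: 158 nM in a functional assay on CHO cells for antagonist activity at Orexin receptor type 2 (Homo sapiens), read by FLIPR and calcium flux; a lower number here means a stronger inhibitor, a higher number a weaker inhibitor
Compound 2 `Cc1occc1-c1nnc(SCC(=O)Nc2cccc(F)c2)n1Cc1ccco1`: 501 nM in this assay
Compound 3 `Cc1occc1-c1nnc(SCC(=O)Nc2ccc(Cl)cc2)n1Cc1ccco1`: 100 nM in this assay

Compound 3 has the lowest number of the three, though its gap to compound 1 is within the scatter a 1.6-fold lower number from compound 1 to compound 3 (0.20 log units; within the scatter); only compound 2 stands clearly apart a 5.0-fold lower number from compound 2 to compound 3 (0.70 log units; beyond the scatter). The step to compound 4 `Cc1occc1-c1nnc(SCC(=O)Nc2ccc(N(C)C)cc2)n1Cc1ccco1` is dimethylamino in place of chloro on an aromatic carbon. Within the data shown here, the one step at this position, chloro for fluoro from compound 1 to compound 3, barely moved the number a 1.6-fold lower number from compound 1 to compound 3 (0.20 log units; within the scatter), but no measured step exchanges a halogen for a dimethylamino group, so the direction is uncertain. A modest weakening is expected for compound 4 in this assay, a 2.5-fold higher number from compound 3 to compound 4 (0.40 log units; beyond the scatter). The estimate for compound 4 is 250 nM, between 80 nM and 800 nM.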

Compound 4, inhibition constant: 158 nM
The estimate for compound 4 lay 1.6-fold (0.20 log units) above the measured number; low and high end bracket the measured number.
By their numbers in this assay, from the lowest: compounds 3, 1 and 4 (each within the scatter of the next); then compound 2.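

At this spot on the aromatic ring, dimethylamino reads much like the halogens in this assay: its swap for chloro (a 1.6-fold higher number from compound 3 to compound 4 (0.20 log units; within the scatter)) and its swap for fluoro (no change at the digits printed from compound 1 to compound 4 (within the scatter)) both leave the number within the scatter. Only the 3-fluorophenyl group stands apart (a 3.2-fold lower number from compound 2 to compound 4 (0.50 log units; beyond the scatter)). Nothing available explains why such different groups read alike.

On these data alone, whether a carboxylic acid or a longer chain on this carbon would also read the same remains open. So does whether chloro or dimethylamino, placed as the fluoro is in the 3-fluorophenyl group, would raise the number too.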